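This account rests on a few compounds, and the source may have more. Where it says the series, first, only, none or still open, it means among the compounds named here.

Working notes on the series. Among the compounds with values here, compound 2 `COc1cc2c(Oc3ccc(NC(=O)c4nn(-c5ccccc5)c(=O)c5ccccc45)cc3F)ccnc2cc1OCCCN1CCN(C)CC1` gives 450 nM in a functional assay on NCI-H460 cells (Homo sapiens) for cytotoxicity, read by MTT assay, with a stated time of 72 h (on this read-out lower numbers stand for stronger inhibition and higher numbers for weaker inhibition), and stands second highest of the three numbers so far: compound 1 `COc1cc2c(Oc3ccc(NC(=O)c4nn(-c5ccccc5)c(=O)c5ccccc45)cc3F)ccnc2cc1OCCCN1CCCC1` gives 480 nM in this assay, the nearest, and compound 3 `COc1cc2c(Oc3ccc(NC(=O)c4nn(-c5ccccc5F)c(=O)c5ccccc45)cc3F)ccnc2cc1OCCCN1CCN(C)CC1` gives 230 nM in this assay, the furthest, both within the scatter of compound 2.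

The step to compound 4 `COc1cc2c(Oc3ccc(NC(=O)c4nn(-c5ccccc5)c(=O)c5ccccc45)cc3F)ccnc2cc1OCCCN1CCCCC1` is piperidin-1-yl in place of 4-methylpiperazin-1-yl on a saturated chain carbon, three bonds along the chain from an oxygen on an aromatic ring. Within the data shown here, the one measured step at the same place, a 1.1-fold lower number from compound 1 to compound 2 (0.03 log units; within the scatter), exchanged one saturated amine ring for another with no movement beyond the scatter. The other step, a 2.0-fold lower number from compound 2 to compound 3 (0.29 log units; within the scatter), sits elsewhere, at the fluoro in place of hydrogen on an aromatic carbon, and also stayed within the scatter, so no measured step in this series gives a reason to expect a change beyond the scatter in this assay here.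

Compound 4 is therefore expected to show no change at the digits printed from compound 2 to compound 4 (within the scatter), an estimate of 450 nM in this assay with a range from 200 nM to 1000 nM.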

Compound 4, half-maximal inhibitory concentration: 650 nM
Compound 4: the middle estimate sits 1.4-fold (0.16 log units) below what was measured; the range from low to high includes it.
By their numbers in this assay, from the lowest: compounds 3, 2, 1 and 4 (each within the scatter of the next, the first and the last beyond it).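

In this assay, the piperidin-1-yl ring gives a 1.4-fold higher number from compound 2 to compound 4 (0.16 log units; within the scatter) against the 4-methylpiperazin-1-yl ring, so removing the second ring nitrogen along with its methyl group leaves the number within the scatter at this place on the chain. The six-membered piperidin-1-yl ring and the pyrrolidin-1-yl ring also stay within the scatter of each other, with a 1.4-fold higher number from compound 1 to compound 4 (0.13 log units; within the scatter) for that exchange, and compounds 1, 2 and 4 therefore cannot be ranked. No measurement shown here bears on why these saturated amine rings read alike.

Going by these compounds, whether the same holds for morpholin-4-yl, for an open dimethylamino group, for a carboxylic acid in place of the amine or for a longer chain remains open. Also open, on these data alone, is whether the aromatic fluoro of compound 3 would read the same alongside the piperidin-1-yl ring.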